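The compounds below may be only part of what the source reports. "The series", "measured", "known", "first", "only" and "open" are said of these compounds alone.

Measured so far in an ADME assay on J774 cells (Mus musculus) for cytotoxicity; on this read-out higher numbers stand for an effect only at larger amounts of compound and lower numbers for an effect already at smaller amounts:
- Compound 1 `CCCCc1cc2c(=O)c(C(=O)OCC)c[nH]c2cc1OCCOc1ccccc1` gives > 20000 nM (a limit)
- Compound 2 `COC(=O)c1c[nH]c2ccc(OCc3ccccc3)cc2c1=O` gives 7590 nM

The entry for compound 1, > 20000 nM, is a limit of the assay and not a number. For the measured compounds named here, compound 2, at 7590 nM, holds the only actual number so far. Compound 3 `COC(=O)c1c[nH]c2ccc(OCCc3ccccc3)cc2c1=O` differs from it in one place: benzyl in place of phenyl on a saturated chain carbon bound to an oxygen on an aromatic ring. Going by the values given here, no measured step yet shows what such a change does in this assay, and no shift beyond the usual scatter is expected in either direction. The expected step is a 1.1-fold lower number from compound 2 to compound 3 (0.04 log units; within the scatter). For compound 3 the estimated value is 7000 nM, with an expected range of 3000 nM to 16000 nM.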

Compound 3, half-maximal effective concentration: 2200 nM
Beside the measured number, compound 3's estimate is 3.2-fold (0.50 log units) above it; measured number outside the range, below it.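

For the compounds shown here, the change from benzyl to phenethyl on the oxygen gives a 3.5-fold lower number from compound 2 to compound 3 (0.54 log units; beyond the scatter) in this assay and is the first step that can be read at this place. It shows that the number on this read-out responds to a change of this size on a saturated chain carbon bound to an oxygen on an aromatic ring. Nothing measured here points to a cause for this shift.

A single step does not show whether a longer chain such as phenylpropyl would lower the number further. From the compounds shown here alone, how an amine or a carboxylic acid on this chain would act also stays open.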